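From Fluorobenzyl to Methoxybenzyl on a Shared Core

This account rests on a few compounds, and the source may have more. Where it says the series, first, only, none or still open, it means among the compounds named here.

Measured so far:
compound 1, `COc1ccc(-c2ccc3c(c2)C(=O)C(=O)N3Cc2ccc(F)cc2)cc1`, 1120 nM
compound 2, `COc1ccc(-c2ccc3c(c2)C(=O)C(=O)N3Cc2ccc(Br)cc2)cc1`, 700 nM

In a functional assay on HepG2 cells (Homo sapiens) for antiproliferative activity, read by MTT assay, with a stated time of 48 h (a lower number here means a stronger inhibitor, a higher number a weaker inhibitor), compound 1 gives the higher of the two numbers; its nearest neighbour is compound 2, and a 1.6-fold lower number from compound 1 to compound 2 (0.20 log units; within the scatter). Compound 3, `COc1ccc(-c2ccc3c(c2)C(=O)C(=O)N3Cc2cccc(OC)c2)cc1`, is changed at the same place: 3-methoxyphenyl in place of 4-fluorophenyl on a saturated chain carbon bound to an amide-type nitrogen in a ring. For the measured compounds named here, the only measured step exchanges one halogen for another and lies within the scatter, so nothing here shows how 3-methoxyphenyl in place of 4-fluorophenyl on a saturated chain carbon bound to an amide-type nitrogen in a ring will read. No step beyond the scatter is expected in this assay. Compound 3 is therefore estimated at 1000 nM, between 400 nM and 2500 nM. That expected step is a 1.1-fold lower number from compound 1 to compound 3 (0.05 log units; within the scatter).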

Compound 3, half-maximal inhibitory concentration: 700 nM
Estimate against measurement, compound 3: 1.4-fold (0.15 log units) above, within the range that was stated.
By their numbers in this assay, from the lowest: compounds 2, 3 and 1 (each within the scatter of the next).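

In this assay the move to 3-methoxyphenyl gives a 1.6-fold lower number from compound 1 to compound 3 (0.20 log units; within the scatter) and no change at the digits printed from compound 2 to compound 3 (within the scatter) at this place, on a saturated chain carbon bound to an amide-type nitrogen in a ring. The earlier step only exchanged one halogen for another, whereas this change removes the halogen, moves the substituent and brings in a hydrogen-bond acceptor, yet both steps stay within the scatter. Nothing measured here offers a reason for this result. The compounds shown leave open whether an amine or a carboxylic acid on this aromatic ring, or a longer chain carrying it, would give a step beyond the scatter.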